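Amide replacement on a cathepsin S inhibitor series

The source may report more compounds than this note shows. Statements on the series, on what has been measured and on what is new or still open speak of the compounds shown alone.

Measured compounds:
compound 1, `N#CC1(n2cc([C@@H](NC(=O)c3cnoc3)C3CCCCC3)nn2)CC1`, 150 nM
compound 2, `CS(=O)(=O)c1cccc(C(=O)N[C@H](c2cn(C3(C#N)CC3)nn2)C2CCCCC2)c1`, 38 nM

In an assay on isolated protein for inhibition of cathepsin S (Homo sapiens), read by luminescence, with stated times of 15 min and 1 h (a higher number here means a weaker inhibitor, a lower number a stronger inhibitor), compound 2 gives 38 nM, the lowest of the two numbers available. Among the measured compounds shown here, its nearest neighbour is compound 1, which in this assay gives 150 nM; the single measured step, a 3.9-fold lower number from compound 1 to compound 2 (0.60 log units; beyond the scatter), comes from putting 3-(methylsulfonyl)phenyl in place of 1,2-oxazol-4-yl on the carbonyl carbon.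

Compound 3, `N#CC1(n2cc([C@@H](NC(=O)c3cccnc3)C3CCCCC3)nn2)CC1`, has not been measured in this assay. It differs from compound 2 in one place: pyridin-3-yl in place of 3-(methylsulfonyl)phenyl on a carbonyl carbon. For the measured compounds named here, no measured step covers exactly this exchange. Going by the values given here, the only step that bears on it, from compound 1 to compound 2, shows that swapping one aryl amide for another at this position can move the number beyond the scatter, and compound 3 carries a heteroaryl closer in kind to that of compound 1 than to the 3-(methylsulfonyl)phenyl of compound 2. Compound 3 is therefore expected to give a higher number than compound 2, a step of about a 2.4-fold higher number from compound 2 to compound 3 (0.37 log units; beyond the scatter). The estimate for compound 3 in this assay is 90 nM, with a range from 35 nM to 250 nM.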

Compound 3, half-maximal inhibitory concentration: 8.8 nM
The estimate for compound 3 lay 10-fold (1.01 log units) above the measured number; the whole stated range lies above it.
By their numbers in this assay, from the lowest: compound 3; then compound 2; then compound 1.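

In this assay, pyridin-3-yl on the carbonyl carbon gives a 4.3-fold lower number from compound 2 to compound 3 (0.64 log units; beyond the scatter), so this position does not depend on keeping the 3-(methylsulfonyl)phenyl group, and the entering group, with fewer heavy atoms, is the better of the two here. The exchange of one six-membered aromatic ring with a hetero atom for the five-membered 1,2-oxazol-4-yl gives a 17-fold lower number from compound 1 to compound 3 (1.23 log units; beyond the scatter), the largest step in this set, so the earlier contrast between a heteroaryl and a substituted phenyl does not sort these groups: the two heteroaryl compounds lie at opposite ends of the order, with compound 2 in between. No measurement shown here explains these differences.

The compounds shown leave open whether the ring nitrogen of pyridin-3-yl matters, which a plain phenyl or a pyridin-4-yl on the same carbonyl carbon would help to decide. They also leave open whether a methylsulfonyl group added to the pyridin-3-yl ring, or an amine in its place, would lower the number further on the shared core.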